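The compounds below may be only part of what the source reports. "The series", "measured", "known", "first", "only" and "open" are said of these compounds alone.

Values in a functional assay on KB cells (Homo sapiens) for inhibition; a lower number here means a stronger inhibitor, a higher number a weaker inhibitor:

- compound 1 `Nc1nc2cc(Cl)c(Cl)cc2n1Cc1ccc(F)cc1`: 70000 nM
- compound 2 `CC(C)(C)c1ccc(Cn2c(Cl)nc3cc(Cl)c(Cl)cc32)cc1`: > 100000 nM (a limit of the assay, not a number)

Compound 2 stands at the limit of > 100000 nM in this assay, at which 1 of the 2 values shown sits. Within the data shown here, it therefore has no exact position, and the series so far holds no measured step that changes a single place.

Next in line is compound 3 `Fc1ccc(Cn2c(Cl)nc3cc(Cl)c(Cl)cc32)cc1`, which differs from compound 2 at one point: fluoro in place of tert-butyl on an aromatic carbon. Compound 3 keeps the rest of compound 2 and shares the fluoro group with compound 1.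

Among the measured compounds shown here, with no measured step to draw on, only a modest change towards stronger inhibition is expected in this assay. For the measured compounds named here, the one firm anchor is compound 1 at 70000 nM, so a weak value of similar order is expected for compound 3. A further reading at the limit of the assay would not be surprising for compound 3. The expected size of the change is an at least 1.6-fold lower number from compound 2 to compound 3 (0.22 log units; that floor lies within the scatter). For compound 3 the estimate is 60000 nM, with an expected range of 20000 nM to 100000 nM.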

Compound 3, half-maximal inhibitory concentration: > 100000 nM
Compound 3 ended at the assay's limit; the forecaster's own chance of this, stated with the estimate: 40%; at least 1.6-fold (0.22 log units) between middle value and limit.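

In this assay, fluoro in place of tert-butyl, on an aromatic carbon para to a large group, leaves the series at the assay's limit, so that neither group gives a number here: the limit of > 100000 nM in this assay, at which 2 of the 3 values shown sit. Both ends of this change are limits, so the step cannot be read and says nothing on whether tert-butyl and fluoro differ at this place. The pair sharing the fluoro group gives the only readable comparison, chloro in place of amino on an aromatic carbon, with an at least 1.4-fold higher number from compound 1 to compound 3 (0.15 log units; that floor lies within the scatter), so the amino group of compound 1 is not shown to matter beyond the scatter, although compound 1 alone carries a measured number.

Open, going by these compounds, is whether a carboxylic acid or a longer chain in place of fluoro would bring the reading off the limit at all. Also open, on these data alone, is whether a methylamino or hydroxyl group in place of chloro would give a number clearly lower than that of compound 1, at 70000 nM, or whether the whole series stays this weak in this assay.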